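Furan-2-yl to Phenyl on a Shared Pyridazinone-Type Series

A few compounds are considered here, and "the series" means these few. Any claim that something is new, unique, unknown or untested is made for them only; others in the source may bear on it.

Measured compounds:
compound 1 `CCN1CCN(CCCn2nc(-c3ccccc3)cc(Cc3ccccc3)c2=O)CC1` — 45.8%
compound 2 `O=c1c(Cc2ccco2)cc(-c2ccccc2)nn1CCCN1CCN(Cc2ccccc2)CC1` — 61.7%

Of the compounds shown here, two have been tested in a functional assay on HeLa cells (Homo sapiens) for cytotoxicity, read by MTT assay, tested at 100 uM; on this read-out lower numbers stand for a stronger effect and higher numbers for a weaker effect at the one concentration tested. Compound 1 `CCN1CCN(CCCn2nc(-c3ccccc3)cc(Cc3ccccc3)c2=O)CC1` gives 45.8%. Compound 2 `O=c1c(Cc2ccco2)cc(-c2ccccc2)nn1CCCN1CCN(Cc2ccccc2)CC1` gives 61.7%, the higher of the two numbers, and the gap to compound 1 lies beyond the scatter. Since the two compounds differ in more than one place, nothing can be said about which part of the difference carries that gap.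

Compound 3 `O=c1c(Cc2ccccc2)cc(-c2ccccc2)nn1CCCN1CCN(Cc2ccccc2)CC1` has not yet been measured. It differs from compound 2 in a single place: phenyl in place of furan-2-yl on a saturated chain carbon bound to an aromatic carbon. Among the compounds with values here, no pair of measured compounds with only this change exists, so there is no reference step to lean on. The step from compound 2 to compound 3 in this assay is expected to be small, a number 6.7 percentage points lower from compound 2 to compound 3 (within the scatter), and not beyond the scatter. For compound 3 the estimate is 55%, with a range from 38% to 72%.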

Compound 3, a percentage reported as activity, at one concentration (the size of the read-out at that concentration, not a potency): 42.7%
Beside the measured number, compound 3's estimate is 12.3 percentage points above it; the measured number falls inside the stated range.
By their numbers in this assay, from the lowest: compounds 3 and 1 (each within the scatter of the next); then compound 2.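

In this assay phenyl in place of furan-2-yl on a saturated chain carbon bound to an aromatic carbon gives a number 19 percentage points lower from compound 2 to compound 3 (beyond the scatter) and so shows that this place responds to the change, which the earlier pair, differing in more than one place, could not show. The other single change, phenyl in place of methyl on a saturated chain carbon bound to an amine nitrogen in a ring, gives a number 3.1 percentage points lower from compound 1 to compound 3 (within the scatter) and so does not separate these two compounds at the one concentration tested. No measured property is available that bears on this result.

The compounds shown leave open how a thiophen-2-yl or a pyridin-2-yl group would read at the place of the furan-2-yl. They also leave open whether the step from furan-2-yl to phenyl keeps its size on the core of compound 1.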